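A single substituent swap on the most potent compound

This account rests on a few compounds, and the source may have more. Where it says the series, first, only, none or still open, it means among the compounds named here.

Measurements in an assay on CHO cells for displacement of a labelled ligand from Substance-P receptor (Homo sapiens) (on this read-out higher numbers stand for weaker inhibition and lower numbers for stronger inhibition), exist for three compounds. Compound 1 `Fc1ccc(C2NCCOC23CCC(c2cccc(C(F)(F)F)c2)CO3)cc1` gives 513 nM. Compound 2 `Fc1ccc([C@@H]2NCCOC23COC[C@H](c2cccc(C(F)(F)F)c2)C3)cc1` gives 30 nM. Compound 3 `COc1ccc(-n2nnnc2C(F)(F)F)cc1[C@H]1COCC2(C1)OCCN[C@H]2c1ccc(F)cc1` gives 0.1 nM, the lowest of the three numbers, and its distance from each of the other two is beyond the usual scatter, so compound 3 is the strongest binder among them. Compound 4 `COc1ccc(OC)c([C@H]2COCC3(C2)OCCN[C@H]3c2ccc(F)cc2)c1` has not yet been measured in this assay and differs from compound 3 in one place: methoxy in place of 5-(trifluoromethyl)-1H-tetrazol-1-yl on an aromatic carbon. Among the compounds with values here, no pair of measured compounds differs in this single place, so the step cannot be read off from the earlier numbers. Given that compound 3 sits at 0.1 nM, the step from compound 3 to compound 4 is expected to move the number upward, toward weaker inhibition, by a clearly noticeable amount, a 30-fold higher number from compound 3 to compound 4 (1.48 log units; beyond the scatter), while still leaving compound 4 well away from compound 2 at 30 nM. Compound 4 is therefore estimated at 3 nM, within a range of 0.5 nM to 20 nM.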

Compound 4, half-maximal inhibitory concentration: 16 nM
Beside the measured number, compound 4's estimate is 5.3-fold (0.73 log units) below it; measured number inside the range.
By their numbers in this assay, from the lowest: compound 3; then compounds 4 and 2 (each within the scatter of the next); then compound 1.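

In this assay, within the data shown here, methoxy in place of 5-(trifluoromethyl)-1H-tetrazol-1-yl on this aromatic carbon gives a large step, a 160-fold higher number from compound 3 to compound 4 (2.20 log units; beyond the scatter), the first reading of this position, which no earlier pair of compounds isolated. The number therefore depends strongly on the group at this place, para to a methoxy group, although compound 4 still gives 16 nM without the five-membered aromatic ring. Nothing measured here accounts for the size of this step.

The trifluoromethyl group and the tetrazole ring leave together in this one step, so the compounds shown cannot divide the effect between them. Also open, on these data alone, is how an unsubstituted 1H-tetrazol-1-yl, a nitrile or an amine at this carbon would read.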